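Changing the acid side chain of compound 3

The compounds below may be only part of what the source reports. "The series", "measured", "known", "first", "only" and "open" are said of these compounds alone.

Measured so far in a functional assay for inhibition of Polyunsaturated fatty acid 5-lipoxygenase (Homo sapiens); a lower number here means a stronger inhibitor, a higher number a weaker inhibitor:
compound 1, `C/C(=N\OC(c1ccc(OCc2ccc3cc(F)ccc3n2)cc1)C1CCCCC1)C(=O)O`, 20 nM
compound 2, `C/C(=N\OC(c1ccc(OCc2cscn2)cc1)C1CCCCC1)C(=O)O`, 360 nM
compound 3, `O=C(O)/C=N/OC(c1ccc(OCc2nc(-c3ccccc3)cs2)cc1)C1CCCCC1`, 21 nM

Compound 3 sits in the middle of these three numbers. Its value and that of compound 1 lie within the usual scatter of each other, so nothing separates them; compound 2 gives a clearly higher number, beyond the scatter. Within the data shown here, the only single-point step measured so far is an 18-fold higher number from compound 1 to compound 2 (1.26 log units; beyond the scatter), and it concerns the aromatic group hanging from the ether oxygen, not the acid side chain.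

Compound 4, `C/C(=N\OC(c1ccc(OCc2nc(-c3ccccc3)cs2)cc1)C1CCCCC1)C(=O)O`, differs from compound 3 only in that side chain: a group of 6 heavy atoms (3 carbon, 1 nitrogen, 2 oxygen; no ring) in place of a group of 5 heavy atoms (2 carbon, 1 nitrogen, 2 oxygen; no ring), on an oxygen on a saturated carbon. Among the measured compounds shown here, compound 1 and compound 2 both carry the chain that enters here, while compound 3 carries the chain that leaves, but no measured pair isolates this exchange, so no step bears directly on it. With the aromatic group and the rest of the molecule unchanged, and given that compound 3 already gives a low number, the expectation is a small step, likely within the scatter, in either direction: a 1.0-fold higher number from compound 3 to compound 4 (0.02 log units; within the scatter). Compound 4 is therefore estimated at 22 nM in this assay, with a range from 8 nM to 60 nM.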

Compound 4, half-maximal inhibitory concentration: 20 nM
For compound 4 the middle estimate is 1.1-fold (0.04 log units) above the measured one; the range from low to high includes it.
By their numbers in this assay, from the lowest: compounds 1, 4 and 3 (each within the scatter of the next); then compound 2.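

In this assay, the chain of 6 heavy atoms in place of the chain of 5 heavy atoms gives a 1.1-fold lower number from compound 3 to compound 4 (0.02 log units; within the scatter) and so leaves the number unchanged within the usual scatter, at least with 4-phenyl-1,3-thiazol-2-yl as the aromatic group. Among these compounds, compound 4 also gives the first comparisons of aromatic groups beyond the original pair: 4-phenyl-1,3-thiazol-2-yl in place of 1,3-thiazol-4-yl gives an 18-fold lower number from compound 2 to compound 4 (1.26 log units; beyond the scatter) while the same group in place of 6-fluoroquinolin-2-yl gives no change at the digits printed from compound 1 to compound 4 (within the scatter) and thus matches the fused ring group within the scatter. No measurement here explains why the side chain exchange makes so little difference or why the aromatic groups differ as they do.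

The compounds shown leave open whether the side chain exchange would be just as small with 1,3-thiazol-4-yl or 6-fluoroquinolin-2-yl as the aromatic group. They also leave open what would happen with a larger change at this position, such as a methyl ester or an amide in place of the carboxylic acid, or a longer chain carrying that acid.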